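The compounds below may be only part of what the source reports. "The series", "measured", "known", "first", "only" and "open" are said of these compounds alone.

Compound 2 `CCOC(=O)C1=C(C)NC(C)=C(C(=O)OCC)C1c1ccc(OCC(=O)n2nc(C)cc2C)cc1` and compound 1 `CCOC(=O)C1=C(C)NC(C)=C(C(=O)OCC)C1c1ccc(OCC(=O)Nc2ccc(C)cc2)cc1` share one core and differ only in the group attached to a carbonyl carbon. In a functional assay on the whole organism (strain Wistar) for inhibition, with Rattus norvegicus as the target, read by paw edema, with stated times of 30 min and 0.5 h, at a dose of 20 mg/kg (on this read-out lower numbers stand for less inhibition and higher numbers for more inhibition at the one dose given (going by the name of the read-out)), compound 1 gives 43.9%, while compound 2 gives 13.7%. Of these two numbers compound 2 stands lowest, and the step of a number 30.2 percentage points lower from compound 1 to compound 2 (beyond the scatter) shows that exchanging the group on that carbonyl carbon can shift the read-out a long way. For the measured compounds named here, compound 3 `CCOC(=O)C1=C(C)NC(C)=C(C(=O)OCC)C1c1ccc(OCC(=O)NNC(=O)CCC(=O)O)cc1` awaits measurement. a group of 9 heavy atoms (4 carbon, 2 nitrogen, 3 oxygen; no ring) in place of a group of 7 heavy atoms (5 carbon, 2 nitrogen; one five-membered aromatic ring with 2 hetero atoms), on a carbonyl carbon Only the step from compound 1 to compound 2 bears on this change, and it was large: the 3,5-dimethyl-1H-pyrazol-1-yl group went with the low number, so its departure is expected to raise the read-out, although the entering group is unlike the (4-methylphenyl)amino of compound 1. For compound 3 the expected step is a number 16.3 percentage points higher from compound 2 to compound 3 (beyond the scatter). Compound 3 is therefore estimated at 30%, with a range from 10% to 52%.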

Compound 3, a percentage reported as inhibition, in the whole organism at one dose (the size of the read-out at that dose, not a potency): 34.9%
For compound 3 the middle estimate is 4.9 percentage points below the measured one; the measured number falls inside the stated range.
By their numbers in this assay, from the lowest: compound 2; then compounds 3 and 1 (each within the scatter of the next).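

Moving from a ring to an open chain on the carbonyl carbon gives, in this assay, a number 21.2 percentage points higher from compound 2 to compound 3 (beyond the scatter), so the low number of compound 2 is not shared by every replacement of the 3,5-dimethyl-1H-pyrazol-1-yl group. The step of a number 9 percentage points lower from compound 1 to compound 3 (within the scatter), with ((2-carboxyethyl)carbonyl)amino in place of 4-methylphenyl on an amide-type nitrogen, shows that these two quite different groups cannot be told apart here, and that a group with no ring can match one that carries an aromatic ring. Nothing measured here accounts for these differences.

On these data alone, it remains open whether the carboxylic acid at the end of the chain in compound 3 matters. A methyl ester in its place, or a longer chain, would test this.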